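Solubility notes: compound 1 to compound 4

The compounds below may be only part of what the source reports. "The series", "measured", "known", "first", "only" and "open" are said of these compounds alone.

Compound 1 `FC(F)(F)c1cccc(-c2nc3cnc(Nc4ccncn4)cc3[nH]2)c1` gives 200000 nM in a physicochemical assay for solubility, using the shake flask method, measured as kinetic solubility, with a stated time of 20 h, at pH 2 (a lower number here means a less soluble compound, a higher number a more soluble compound), the highest of the three numbers recorded so far. Compound 3 `Fc1ccnc(Nc2cc3[nH]c(-c4ccc(F)c(F)c4)nc3cn2)c1` gives 166000 nM, which sits within the scatter of compound 1. Compound 2 `Fc1ccc(-c2nc3cnc(Nc4ccccn4)cc3[nH]2)cc1C(F)(F)F` gives 7000 nM, well beyond the scatter and the clear low point of the set. The next compound, compound 4 `O=C(O)c1ccc(Nc2cc3[nH]c(-c4cccc(C(F)(F)F)c4)nc3cn2)nc1`, differs from compound 1 in one place: 5-carboxypyridin-2-yl in place of pyrimidin-4-yl on a nitrogen on an aromatic ring. For the measured compounds named here, no measured pair in the set isolates this change, so the step can only be guessed. A modest drop is expected, with the step of a 2.2-fold lower number from compound 1 to compound 4 (0.35 log units; beyond the scatter) judged only slightly beyond the scatter. Compound 4 is accordingly estimated at 90000 nM, within a range of 20000 nM to 400000 nM.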

Compound 4, solubility: < 5000 nM
Compound 4 gave a limit, no number; the forecaster's own chance of this, stated with the estimate: 10%; middle value at least 18-fold (1.25 log units) away from the limit.
By their numbers in this assay, from the lowest: compound 2; then compounds 3 and 1 (each within the scatter of the next). At a limit, below all of these: compound 4.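

In this assay, this place on a nitrogen on an aromatic ring proves sensitive: 5-carboxypyridin-2-yl in place of pyrimidin-4-yl gives an at least 40-fold lower number from compound 1 to compound 4 (1.60 log units; beyond the scatter). For the compounds shown here, this is the first step in the set that reads a single change, since compounds 1, 2 and 3 differ from one another in more than one place. Compound 4 gives a limit, not a number: the limit of < 5000 nM in this assay, at which 1 of the 4 values shown sits.

From the compounds shown here alone, whether the step follows the carboxylic acid or the change of ring stays open. A methyl ester, an amide or an amine in place of the carboxylic acid, on the same core, would bear on that question.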